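Oxadiazolone series: methoxy in place of the aryl ester

The source may hold more compounds than are shown below. What is called first, only, known or untested is meant among the compounds shown, and "the series" means these compounds.

Compound 1 `COc1nn(Cc2ccccc2)c(=O)o1`: "not active" (no number reported)
Compound 2 `COc1nn(Cc2cccc(NC(C)=O)c2)c(=O)o1`: "not active" (no number reported)
Compound 3 `COC(=O)c1cccc(Cn2nc(OC)oc2=O)c1`: 20%

Three compounds have been run in an assay on COS-7 cells for inhibition of Fatty-acid amide hydrolase 1 (Homo sapiens), read by scintillation counting, with a stated time of 10 min, tested at 10 uM; a lower number here means less inhibition, a higher number more inhibition at the concentration tested (going by the name of the read-out). Compound 1 and compound 2 are reported without a number. Compound 3 is the only entry with a figure, 20%, so it stands as the single quantified point of the series, and a modest one at the concentration tested. Going by the values given here, no step between two measured compounds is available in this assay.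

Compound 4 `COc1cccc(Cn2nc(OC)oc2=O)c1` differs from compound 3 by methoxy in place of methoxycarbonyl on an aromatic carbon. With one number to go on and two entries that gave none, the step of a number 8 percentage points lower from compound 3 to compound 4 (within the scatter) is expected to be small, downward or none beyond the scatter. Compound 4 is therefore estimated at 12% in this assay, with a range from 0% to 30%, and a real chance that only a limit is reported.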

Compound 4, a percentage reported as inhibition, at one concentration (the size of the read-out at that concentration, not a potency): "not active" (no number reported)
For compound 4 the study gives words and no number, so the estimate cannot be set against anything.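

No step can be read from compound 3 to compound 4 in this assay, as compound 4 has words and no number. No measured evidence bears on this result. As far as these compounds go, whether any substituent on this core gives more inhibition than compound 3 remains open.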